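Reading a limit across a fluoro to amino swap

The source may hold more compounds than are shown below. What is called first, only, known or untested is meant among the compounds shown, and "the series" means these compounds.

Measured in an ADME assay on MT4 cells (Homo sapiens) for cytotoxicity, read by MTT assay; a higher number here means that more compound is tolerated, a lower number that less compound is tolerated:
- Compound 1 `Cc1cc(C)cc(S(=O)(=O)c2c(C(=O)NCc3ccccc3F)[nH]c3ccc(Cl)cc23)c1`: > 53000 nM, a limit
- Compound 2 `Cc1cc(C)cc(S(=O)(=O)c2c(C(=O)NCc3ccc(F)cc3)[nH]c3ccc(Cl)cc23)c1`: > 53000 nM, a limit

Compound 2 gives only a limit, > 53000 nM, and no exact number. The other measured value is also a limit, so compound 2 cannot be ranked against compound 1.

Compound 3 `Cc1cc(C)cc(S(=O)(=O)c2c(C(=O)NCc3ccc(N)cc3)[nH]c3ccc(Cl)cc23)c1` keeps the rest of compound 2 but has amino in place of fluoro on an aromatic carbon, para to a large group (amino in place of fluoro on an aromatic carbon). Within the data shown here, only one measured step bears on this change: a step that the two limits leave unreadable from compound 1 to compound 2. That step moves the fluoro group, replacing 2-fluorophenyl with 4-fluorophenyl, and does not introduce amino. Its size cannot be read, so it gives only weak guidance. The evidence available is the limit of > 53000 nM in this assay, at which 2 of the 2 values shown sit.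

With no readable step to build on, no change beyond the usual scatter is expected in this assay, although a value somewhat lower than the limit remains possible. The expected step is an at least 1.1-fold lower number from compound 2 to compound 3 (0.07 log units; that floor lies within the scatter). For compound 3 the estimated value is 45000 nM, with an expected range from 15000 nM to 80000 nM.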

Compound 3, half-maximal cytotoxic concentration: 6370 nM
The estimate for compound 3 lay 7.1-fold (0.85 log units) above the measured number; measured number outside the range, below it.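

Among these compounds, this is the first readable step and shows that the group on this aromatic carbon, para to a large group, can matter: in this assay, amino in place of fluoro gives an at least 8.3-fold lower number from compound 2 to compound 3 (0.92 log units; beyond the scatter). The comparison with the other fluoro compound points the same way, with 4-aminophenyl in place of 2-fluorophenyl giving an at least 8.3-fold lower number from compound 1 to compound 3 (0.92 log units; beyond the scatter). The step between the two fluoro compounds cannot be read, so compound 3 is the only compound here with an exact number, and both new steps are minimum sizes set by this limit: the limit of > 53000 nM in this assay, at which 2 of the 3 values shown sit.

The compounds shown leave open whether this lower number belongs to the amino group in particular or would also appear with another replacement for fluoro at this place, such as a hydroxyl, a methoxy or an acetylamino group, and whether a 2-aminophenyl group would give the same result. From the compounds shown here alone, the true size of both steps also stays open: the two fluoro compounds give only limits, not exact numbers.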